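The compounds below may be only part of what the source reports. "The series", "measured", "known", "first", "only" and "open" are said of these compounds alone.

Compound 2 `CCCCCCCCCCCCCCCc1cc(=O)c2c(O)c(C)c(OCOC)c(C)c2o1` stands only at a limit in a functional assay on MCF7 cells (Homo sapiens) for antiproliferative activity, read by MTT assay; on this read-out lower numbers stand for stronger inhibition and higher numbers for weaker inhibition: its value, > 67200 nM, is a limit of the assay and not a number. Compound 3 `CCCCCCCCCCCCCCCc1cc(=O)c2c(O)c(C)c(O)c(C)c2o1` also sits at a limit, > 67200 nM, which is the limit of > 67200 nM in this assay, at which 2 of the 3 values shown sit. Compound 1 `CC/C=C\C/C=C\C/C=C\CCCCCCCc1cc(=O)c2c(O)c(C)c(O)c(C)c2o1`, the one unsaturated chain, gives 17500 nM in this assay. The step of an at least 3.8-fold higher number from compound 1 to compound 3 (0.58 log units; beyond the scatter) runs from that unsaturated chain to a saturated one, while the step that the two limits leave unreadable from compound 2 to compound 3 cannot be sized. Compound 4 `CCCC/C=C\CCCCCCCCCc1cc(=O)c2c(O)c(C)c(OCOC)c(C)c2o1` differs from compound 2 by hex-1-en-1-yl in place of hexyl on a saturated chain carbon, nine bonds along the chain from an aromatic carbon. Among the compounds with values here, only the step from compound 1 to compound 3 bears on this change, and read in reverse it suggests a lower number; the expected step is therefore an at least 1.6-fold lower number from compound 2 to compound 4 (0.22 log units; that floor lies within the scatter). For compound 4 the estimated value in this assay is 40000 nM, within 15000 nM to 100000 nM.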

Compound 4, half-maximal inhibitory concentration: > 67200 nM
Compound 4: no number, only a limit (the forecaster's own chance of this, stated with the estimate: 45%); middle value at least 1.6-fold (0.22 log units) from the limit.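

Compound 2 and compound 4 both rest on limits, not numbers, so no step between them can be read: the limit of > 67200 nM in this assay, at which 3 of the 4 values shown sit.

Whether hex-1-en-1-yl in place of hexyl shifts the read-out at all stays open among the compounds shown.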